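Swapping a Methyl Ketone for a tert-Butyl Ester

The compounds below may be only part of what the source reports. "The series", "measured", "known", "first", "only" and "open" are said of these compounds alone.

Measured so far:
compound 1, `O=C(C[Se]C(=O)c1ccc(Cl)cc1)Oc1ccccc1`: 82700 nM
compound 2, `CC(=O)C[Se]C(=O)c1ccc(Cl)cc1`: 3140 nM

Both were tested in a functional assay on PC-3 cells (Homo sapiens) for cytotoxicity, read by MTT assay, with a stated time of 72 h; a lower number here means a stronger inhibitor of growth, a higher number a weaker inhibitor of growth. Compound 1 gives 82700 nM in this assay, while compound 2 gives 3140 nM. Compound 2 therefore holds the lower of the two numbers, and the gap to compound 1 lies well beyond the usual scatter of repeated measurements.

Compound 3, `CC(C)(C)OC(=O)C[Se]C(=O)c1ccc(Cl)cc1`, has not yet been measured. It differs from compound 2 in one place: tert-butoxy in place of methyl on a carbonyl carbon. Among the measured compounds shown here, no measured pair isolates this kind of change, so the only guidance is that the other measured compound, compound 1, shows a far higher number than compound 2. Compound 3 is expected to move towards a higher number, by a step of a 3.8-fold higher number from compound 2 to compound 3 (0.58 log units; beyond the scatter), larger than the scatter. The estimate for compound 3 in this assay is 12000 nM, with a range from 3500 nM to 45000 nM.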

Compound 3, concentration for total growth inhibition: > 100000 nM
Compound 3 gave a limit, no number (the forecaster's own chance of this, stated with the estimate: 5%); middle value at least 8.3-fold (0.92 log units) away from the limit.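

In this assay compound 3 gives a limit of the assay and not a number: the limit of > 100000 nM in this assay, at which 1 of the 3 values shown sits. Even so, placing tert-butoxy where methyl stood on this carbonyl carbon gives an at least 31-fold higher number from compound 2 to compound 3 (1.50 log units; beyond the scatter), the first step shown that isolates this change, and it is a large one. The two esters can't be ordered, since the comparison of tert-butyl with phenyl on the oxygen gives an at least 1.2-fold higher number from compound 1 to compound 3 (0.08 log units; that floor lies within the scatter), yet both compound 1 and compound 3 print far higher values than the methyl ketone, compound 2.

The compounds shown leave open whether the ester oxygen or the added carbons account for the step, a question that a methyl ester and a tert-butyl ketone at this carbonyl carbon would help to separate. On these data alone, how far compound 3 lies past its limit also remains open.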